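Shifting the halogen on the indole ring

The source may hold more compounds than are shown below. What is called first, only, known or untested is meant among the compounds shown, and "the series" means these compounds.

Compound 1 `NC(=O)c1ccc2c(c1)CCOC2CCN1CC=C(c2csc3cc(F)ccc23)CC1` gives 186 nM in an assay on cells for binding affinity to 5-hydroxytryptamine receptor 1B (Homo sapiens), read by radioligand binding; on this read-out higher numbers stand for weaker inhibition and lower numbers for stronger inhibition. Compound 2 `NC(=O)c1ccc2c(c1)CCOC2CCN1CC=C(c2c[nH]c3cc(Cl)ccc23)CC1` reaches only the limit of the method there, > 1000 nM; of the values shown, compound 2 sits at the limit of > 1000 nM in this assay, at which 1 of the 2 values shown sits. That limit came with an at least 5.3-fold higher number from compound 1 to compound 2 (0.73 log units; beyond the scatter). Compound 3 `NC(=O)c1ccc2c(c1)CCOC2CCN1CC=C(c2c[nH]c3ccc(F)cc23)CC1` differs from compound 2 only by 5-fluoro-1H-indol-3-yl in place of 6-chloro-1H-indol-3-yl on a double-bonded ring carbon. For the measured compounds named here, no measured step moves a halogen between two positions on the same indole, so the only anchor is the weak binding of compound 2 itself. For compound 3 the estimate is 1500 nM, within 400 nM to 6000 nM, a step that the limit leaves unreadable from compound 2 to compound 3 that is expected to stay near the limit.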

Compound 3, inhibition constant: > 1000 nM
Compound 3 gave a limit, no number (the forecaster's own chance of this, stated with the estimate: 55%); the middle value does not contradict the limit.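

In this assay, compound 3 gives only a limit, > 1000 nM: the limit of > 1000 nM in this assay, at which 2 of the 3 values shown sit. Placing 5-fluoro-1H-indol-3-yl where 6-fluoro-1-benzothiophen-3-yl stood brings an at least 5.3-fold higher number from compound 1 to compound 3 (0.73 log units; beyond the scatter), so the weak binding is not confined to the 6-chloro indole. Both indole values are limits, so the step between them cannot be read.

From the compounds shown here alone, whether an indole carrying a methoxy group, or no halogen at all, would give a measurable value remains open. So does whether 5-fluoro-1-benzothiophen-3-yl would keep the binding seen with its 6-fluoro counterpart.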